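Swapping the amine substituent: acetylpyrrolidinyl to isopropyl

The compounds below may be only part of what the source reports. "The series", "measured", "known", "first", "only" and "open" are said of these compounds alone.

Measured so far:
- compound 1, `CN(c1nc2ccc(NC(=O)CCc3ccc(C(F)(F)F)cc3)cc2[nH]1)C1CC1`: 24 nM
- compound 2, `CC(=O)N1CCC(N(C)c2nc3ccc(NC(=O)CCc4ccc(C(F)(F)F)cc4)cc3[nH]2)C1`: 30 nM

Both numbers come from an assay on CHO-K1 cells for displacement of a labelled ligand from melanin-concentrating hormone receptor 1 (Homo sapiens), read by scintillation counting; a lower number here means a stronger inhibitor, a higher number a weaker inhibitor. Compound 2 and compound 1 lie within the usual scatter of each other, so neither can be ranked against the other on these two values alone.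

Compound 3, `CC(C)N(C)c1nc2ccc(NC(=O)CCc3ccc(C(F)(F)F)cc3)cc2[nH]1`, has not been measured. It differs from compound 2 in one place: isopropyl in place of 1-acetylpyrrolidin-3-yl on a nitrogen on an aromatic ring. Within the data shown here, the only measured step touches the same place: a 1.3-fold higher number from compound 1 to compound 2 (0.10 log units; within the scatter). That step exchanged a small carbon group for the acetylpyrrolidinyl group and stayed within the scatter, so this position has so far tolerated two rather different substituents without a clear shift. Isopropyl is again a small carbon group, so the expected step of a 1.2-fold lower number from compound 2 to compound 3 (0.08 log units; within the scatter) is none beyond the scatter. Compound 3 is therefore estimated to give 25 nM, with a likely range from 10 nM to 65 nM.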

Compound 3, half-maximal inhibitory concentration: 5.9 nM
Compound 3: the middle estimate sits 4.2-fold (0.63 log units) above what was measured, outside the stated range (below it).
By their numbers in this assay, from the lowest: compound 3; then compounds 1 and 2 (each within the scatter of the next).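

In this assay the substituent on this nitrogen turns out to matter after all: isopropyl stands apart both from 1-acetylpyrrolidin-3-yl (a 5.1-fold lower number from compound 2 to compound 3 (0.71 log units; beyond the scatter)) and from cyclopropyl (a 4.1-fold lower number from compound 1 to compound 3 (0.61 log units; beyond the scatter)). Size alone does not sort these three groups, since two small carbon groups, cyclopropyl and isopropyl, differ beyond the scatter, while cyclopropyl and the much larger 1-acetylpyrrolidin-3-yl do not. Nothing available here gives a reason for this.

Still open, as far as these compounds go, is whether the gain belongs to isopropyl alone or carries over to other open carbon groups, such as a tert-butyl group or a longer chain like n-propyl. From the compounds shown here alone, it is also open how the methyl on the same nitrogen contributes, which a hydrogen or an ethyl group there would test.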